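The source may report more compounds than this note shows. Statements on the series, on what has been measured and on what is new or still open speak of the compounds shown alone.

Working notes on the series. Of the compounds shown here, three have been measured in a functional assay, read by spectrophotometry, with a stated time of 30 min, tested at 10 uM; on this read-out lower numbers stand for a weaker effect and higher numbers for a stronger effect at the one concentration tested. Compound 1 `CC1=CC[C@@H](C(C)(C)O[C@@H]2O[C@H](COC(=O)c3cc(O)c(O)c(O)c3)[C@@H](O)[C@H](O)[C@H]2O)CC1` gives 48.4%; compound 2 `CC1=CC[C@H](C(C)(C)O[C@@H]2O[C@H](COC(=O)c3cc(O)c(O)c(O)c3)[C@@H](O)[C@H](O)[C@H]2O)CC1` gives 46.2%; compound 3 `COc1cc(CC(CO)O[C@@H]2O[C@H](COC(=O)c3cc(O)c(O)c(O)c3)[C@@H](O)[C@H](O)[C@H]2O)ccc1O` gives 56.9%. Compound 2 holds the lowest of the three numbers; the number of compound 1 lies within the scatter of it, while compound 3 stands beyond the scatter above it. Within the data shown here, the one measured step, a number 2.2 percentage points lower from compound 1 to compound 2 (within the scatter), rests on the fact that compounds 1 and 2 differ only in the configuration as drawn and is within the scatter. Compound 4 `C=CCc1ccc(O[C@@H]2O[C@H](COC(=O)c3cc(O)c(O)c(O)c3)[C@@H](O)[C@H](O)[C@H]2O)c(OC)c1` differs from compound 2 by 4-allyl-2-methoxyphenyl in place of 1-methyl-1-(4-methylcyclohex-3-en-1-yl)ethyl on an oxygen on a saturated carbon. Among the measured compounds shown here, no measured step covers this kind of change, so the measured steps give no firm direction; the gap between compound 2 and compound 3 suggests at most a modest rise. Compound 4 is expected to give 52%, in the range 40% to 65%, which means an expected step of a number 5.8 percentage points higher from compound 2 to compound 4 (within the scatter).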

Compound 4, a percentage reported as activity, at one concentration (the size of the read-out at that concentration, not a potency): 60.9%
Compound 4: middle estimate off by 8.9 percentage points, on the low side; low and high end bracket the measured number.
By their numbers in this assay, from the lowest: compounds 2, 1, 3 and 4 (each within the scatter of the next, the first and the last beyond it).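

In this assay, among these compounds, 4-allyl-2-methoxyphenyl in place of 1-methyl-1-(4-methylcyclohex-3-en-1-yl)ethyl gives the first steps at this position that lie beyond the scatter: a number 14.7 percentage points higher from compound 2 to compound 4 (beyond the scatter), and a number 12.5 percentage points higher from compound 1 to compound 4 (beyond the scatter). The rise holds from both configurations of the group that leaves, a reading that rests on one fact: the fact that compounds 1 and 2 differ only in the configuration as drawn. On this oxygen, the aromatic group therefore goes with the higher number in these comparisons.

Which part of 4-allyl-2-methoxyphenyl goes with the rise remains open: the allyl chain, the methoxy group or the aromatic ring itself. Going by these compounds, how an amine or a carboxylic acid on that ring would read is also open.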